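A few compounds are considered here, and "the series" means these few. Any claim that something is new, unique, unknown or untested is made for them only; others in the source may bear on it.

Working notes on the series.

Compound 2 `CN(C)C1CC=C(c2c[nH]c3ccc(Br)cc23)CC1` is the starting point of this step. Among the measured compounds shown here, in an assay on isolated protein for inhibition of sodium-dependent dopamine transporter (Homo sapiens), tested at 1 uM (on this read-out lower numbers stand for less inhibition and higher numbers for more inhibition at the one concentration tested (going by the name of the read-out)), compound 2 gives 95%, the highest of the two numbers measured so far. For the measured compounds named here, the only other measured member, compound 1 `CN(C)C1CC=C(c2c[nH]c3ccc(F)cc23)CC1`, gives 23% in this assay. Going by the values given here, the single step between them, bromo in place of fluoro on an aromatic carbon, produced a number 72 percentage points higher from compound 1 to compound 2 (beyond the scatter), a large move well beyond the usual scatter.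

Compound 3 `CN(C)C1CC=C(c2c[nH]c3ccc(Cl)cc23)CC1` is not yet measured. It differs from compound 2 only by chloro in place of bromo on an aromatic carbon. Among the compounds with values here, the one measured step that bears on this change is the one from compound 1 to compound 2, which swapped one halogen for another at the same aromatic carbon and moved the read-out by a number 72 percentage points higher from compound 1 to compound 2 (beyond the scatter). Chloro is the third group of the same kind at that place, so compound 3 is expected to sit closer to compound 2 than to compound 1 in this assay, with a step of about a number 15 percentage points lower from compound 2 to compound 3 (beyond the scatter) expected, possibly no more than the scatter. For compound 3 the estimate in this assay is 80%, with a range of 55% to 95%.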

Compound 3, a percentage reported as inhibition, at one concentration (the size of the read-out at that concentration, not a potency): 16%
Beside the measured number, compound 3's estimate is 64 percentage points above it; measured number outside the range, below it.
By their numbers in this assay, from the lowest: compounds 3 and 1 (each within the scatter of the next); then compound 2.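

Chloro in place of bromo on this aromatic carbon gives, in this assay, a number 79 percentage points lower from compound 2 to compound 3 (beyond the scatter), so the high read-out of compound 2 is not shared by a second halogen and, among the compounds shown, is found only with bromo. Chloro in place of fluoro gives a number 7 percentage points lower from compound 1 to compound 3 (within the scatter), so compound 1 and compound 3 cannot be told apart here, and the three halogens fall into two levels rather than a graded series, with compound 2 alone at the upper level. The data shown hold no measurement that would account for this split between bromo and the other two halogens.

Still open, going by these compounds, is whether the high read-out extends to iodo or is matched by a non-halogen group such as methyl or nitrile at the same aromatic carbon. Also open, on these data alone, is whether bromo keeps this read-out when the dimethylamino group of the shared core gives way to a methylamino group, and, since this is a single-concentration read-out, how the three compounds would compare as measured potencies.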